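The source may hold more compounds than are shown below. What is called first, only, known or untested is meant among the compounds shown, and "the series" means these compounds.

Compound 1 `CC(C)(C)C(=O)OCC1(CO)C/C(=C/CCCCCCCCCCCCCCC=O)C(=O)O1` in a functional assay on SK-MEL-5 cells (Homo sapiens) for antiproliferative activity (a lower number here means a stronger inhibitor of growth, a higher number a weaker inhibitor of growth), gives > 10 ug/mL, a limit of the assay rather than a number.
Compound 2 `COCCCCCCCCCCC/C=C1\CC(CO)(COC(=O)C(C)(C)C)OC1=O` gives 2.81 ug/mL.
Compound 3 `CC(=O)NCCCCCCCCCCCCCCC/C=C1\CC(CO)(COC(=O)C(C)(C)C)OC1=O` gives > 10 ug/mL, again a limit of the assay.

Within the data shown here, compound 2 thus stands as the only numbered value here; the other two readings sit at the limit of > 10 ug/mL in this assay, at which 2 of the 3 values shown sit. Compound 4 `COC(=O)CCCCCCCCCCCCCC/C=C1\CC(CO)(COC(=O)C(C)(C)C)OC1=O` is derived from compound 2 by 3-(methoxycarbonyl)propyl in place of methoxy on a saturated chain carbon, ten or more bonds along the chain from a double-bonded chain carbon. Among the measured compounds shown here, the one measured step at the same place is an at least 3.5-fold higher number from compound 2 to compound 3 (0.55 log units; beyond the scatter), where a larger group carrying a carbonyl replaced the methoxy and growth inhibition fell to the limit. A similar weakening is expected from the ester here, a 2.3-fold higher number from compound 2 to compound 4 (0.36 log units; beyond the scatter). Compound 4 is therefore estimated at 6.5 ug/mL, with a range from 2.5 ug/mL to 15 ug/mL.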

Compound 4, concentration for 50% growth inhibition: 7.8 ug/mL
The estimate for compound 4 lay 1.2-fold (0.08 log units) below the measured number; the measured number falls inside the stated range.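

Replacing methoxy with 3-(methoxycarbonyl)propyl weakens growth inhibition, but it leaves a measurable value: a 2.8-fold higher number from compound 2 to compound 4 (0.44 log units; beyond the scatter). Thus, this position tolerates a larger group carrying a carbonyl better than compound 3 alone suggested. The ester cannot be separated from the acetamide, given an at least 1.2-fold lower number from compound 3 to compound 4 (0.10 log units; that floor lies within the scatter), and compound 3 reads only as a limit: the limit of > 10 ug/mL in this assay, at which 2 of the 4 values shown sit.

From the compounds shown here alone, whether the weakening follows the added length or the ester stays open. A longer chain ending in methoxy would separate the two, and a carboxylic acid or an amine in the same place remains an open question.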